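The compounds below may be only part of what the source reports. "The series", "measured", "known", "first", "only" and "open" are said of these compounds alone.

Compound 1 `CN1CCC(c2ccc(OCc3ccccc3)c(C(=O)Nc3ccnnc3)c2)CC1`, 20 nM; compound 2 `O=C(Nc1ccnnc1)c1cc(N2CCCC2)ccc1OCc1ccccc1`, 20 nM.

In an assay on Sf9 cells for inhibition of Leucine-rich repeat serine/threonine-protein kinase 2 (Homo sapiens), read by TR-FRET, with stated times of 30 min and 2 h (a lower number here means a stronger inhibitor, a higher number a weaker inhibitor), compound 2 stands level with compound 1. Among the compounds with values here, the one measured step, no change at the digits printed from compound 1 to compound 2 (within the scatter), is within the scatter. Compound 3 `C[C@@H]1CN(c2ccc(OCc3ccccc3)c(C(=O)Nc3ccnnc3)c2)C[C@H](C)O1` differs from compound 2 by 2,6-dimethylmorpholin-4-yl in place of pyrrolidin-1-yl on an aromatic carbon. That step bears on the earlier one only loosely, since the entering ring is larger and carries a second hetero atom, so a modest loss cannot be excluded. Compound 3 is therefore estimated at 30 nM, between 10 nM and 100 nM, the expected step being a 1.5-fold higher number from compound 2 to compound 3 (0.18 log units; within the scatter).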

Compound 3, half-maximal inhibitory concentration: 20 nM
Beside the measured number, compound 3's estimate is 1.5-fold (0.18 log units) above it, and the stated range covers the measured number.
By their numbers in this assay, from the lowest: compounds 1, 2 and 3 (each within the scatter of the next).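

Measured in this assay there is no change at the digits printed from compound 2 to compound 3 (within the scatter) when 2,6-dimethylmorpholin-4-yl replaces pyrrolidin-1-yl, and no change at the digits printed from compound 1 to compound 3 (within the scatter) when it replaces 1-methylpiperidin-4-yl. The position para to a benzyloxy group therefore accepts a six-membered ring with a ring oxygen and two defined stereocentres, and the three compounds read alike. Nothing shown accounts for this sameness.

On these data alone, it remains open whether a carboxylic acid or a primary amine at this position would read level too. As far as these compounds go, the other stereoisomers of the 2,6-dimethylmorpholin-4-yl group also remain open.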